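The compounds below may be only part of what the source reports. "The series", "measured", "known", "first", "only" and "open" are said of these compounds alone.

Compound 1 `CC(=O)Nc1ccc(-c2nc3cc(C(F)(F)F)ccc3n2C)cc1` gives 46000 nM in an ADME assay on MDBK cells (Bos taurus) for cytotoxicity, read by MTT assay, with a stated time of 96 h; on this read-out lower numbers stand for higher toxicity in this test and higher numbers for lower toxicity in this test. Compound 3 `CCC(=O)Nc1ccc(-c2nc3cc(C(F)(F)F)ccc3n2C)cc1` carries methyl in place of hydrogen on a saturated chain carbon bound to a carbonyl carbon and reaches only a limit of this assay, > 100000 nM. That step, an at least 2.1-fold higher number from compound 1 to compound 3 (0.33 log units; beyond the scatter), runs toward less toxicity, though it is only bounded on one side because of the limit of > 100000 nM in this assay, at which 2 of the 3 values shown sit. Compound 2 `CC(=O)Nc1ccc(-c2nc3ccccc3[nH]2)cc1` likewise returns only a limit in this assay, > 100000 nM. The difference between the core of compound 1 and the core of compound 2 is not broken down here. Compound 4 `CCC(=O)Nc1ccc(-c2nc3ccccc3[nH]2)cc1` is not yet measured; it stands to compound 2 as compound 3 stands to compound 1, with the same change methyl in place of hydrogen on a saturated chain carbon bound to a carbonyl carbon at the same place. Compound 4 is expected to sit at or past the limit of this assay, a step that the limit leaves unreadable from compound 2 to compound 4, resting on compound 2 at > 100000 nM and on the direction of an at least 2.1-fold higher number from compound 1 to compound 3 (0.33 log units; beyond the scatter). The estimate for compound 4 is 150000 nM, within 80000 nM to 300000 nM.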

Compound 4, half-maximal cytotoxic concentration: > 100000 nM
Compound 4 was reported as a limit; the forecaster's own chance of this, stated with the estimate: 85%; the middle value lies beyond the limit too.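

Compound 2 and compound 4 both return only a limit in this assay, so no new step can be read from this pair: the limit of > 100000 nM in this assay, at which 3 of the 4 values shown sit.
The compounds shown leave open whether methyl in place of hydrogen changes toxicity in this series when compound 2 is the starting point.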